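Swapping the ether for a dimethylaminopropylsulfanyl chain

The source may report more compounds than this note shows. Statements on the series, on what has been measured and on what is new or still open speak of the compounds shown alone.

Compound 1 `CC(C)Oc1nc(C(C)(C)C)ccc1CNC(=O)C(C)c1ccc(NS(C)(=O)=O)c(F)c1` gives 2.3 nM in an assay on cells for antagonist activity at transient receptor potential cation channel subfamily V member 1 (Homo sapiens), read by FLIPR and calcium flux, with a stated time of 6 min; a higher number here means a weaker inhibitor, a lower number a stronger inhibitor.
Compound 2 `CC(C(=O)NCc1ccc(C(C)(C)C)nc1OCc1ccccc1)c1ccc(NS(C)(=O)=O)c(F)c1` gives 4.4 nM in this assay.

Going by the values given here, compound 2 has one measured neighbour, compound 1, and the only measured step is a 1.9-fold higher number from compound 1 to compound 2 (0.28 log units; within the scatter). Compound 3 `CC(C(=O)NCc1ccc(C(C)(C)C)nc1SCCCN(C)C)c1ccc(NS(C)(=O)=O)c(F)c1` differs from compound 2 by (3-(dimethylamino)propyl)sulfanyl in place of benzyloxy on an aromatic carbon. Among the compounds with values here, the measured step changed an oxygen-linked group only and so bears only loosely on this larger change, which replaces the oxygen linker and its benzyl group entirely; no measured step tests that. With so little to go on, compound 3 is expected to stay near compound 2, with a wide range: the estimated step is a 1.8-fold higher number from compound 2 to compound 3 (0.26 log units; within the scatter), giving an expected 8 nM, between 2 nM and 40 nM.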

Compound 3, inhibition constant: 51.8 nM
Compound 3: the middle estimate sits 6.5-fold (0.81 log units) below what was measured; measured number outside the range, above it.
By their numbers in this assay, from the lowest: compounds 1 and 2 (each within the scatter of the next); then compound 3.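

This position is not indifferent to what sits on it: the isopropoxy and benzyloxy ethers stay within the scatter of each other, yet (3-(dimethylamino)propyl)sulfanyl gives a 12-fold higher number from compound 2 to compound 3 (1.07 log units; beyond the scatter) and a 23-fold higher number from compound 1 to compound 3 (1.35 log units; beyond the scatter), both large weakenings of inhibition. The change replaces the oxygen linker, removes the aromatic ring of the benzyl group and adds a dimethylamino group in a single step. No measurement at hand accounts for the weakening. Which of these parts matters stays open. A benzylsulfanyl group or a 3-(dimethylamino)propoxy chain would begin to separate them.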